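Bromo to trifluoromethyl on two related cores

This account rests on a few compounds, and the source may have more. Where it says the series, first, only, none or still open, it means among the compounds named here.

Of the compounds shown here, three have been measured in a functional assay on HepG2 cells (Homo sapiens) for cytotoxicity, with a stated time of 24 h (on this read-out lower numbers stand for stronger inhibition and higher numbers for weaker inhibition), and a fourth awaits its number. Compound 1 `COc1ccc(Cl)cc1C(=O)Nc1ccc(Br)cc1O` carries a bromo group on the ring that also bears the hydroxy group; in this assay compound 1 gives 7980 nM. Compound 2 `COc1ccc(Cl)cc1C(=O)Nc1ccc(C(F)(F)F)cc1O` is its partner in which the bromo has been replaced, and in this assay compound 2 gives 4910 nM. The change between them is trifluoromethyl in place of bromo on an aromatic carbon, and it made a 1.6-fold lower number from compound 1 to compound 2 (0.21 log units; within the scatter).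

Compound 3 `COc1cc(Cl)ccc1C(=S)Nc1ccc(Br)cc1O` is built on a different core; the difference between the two cores is not broken down here. In this assay compound 3 gives 3880 nM, a number within the scatter of compound 2 and beyond the scatter of compound 1.

Compound 4 `COc1cc(Cl)ccc1C(=S)Nc1ccc(C(F)(F)F)cc1O` is the partner of compound 3 in exactly the same way that compound 2 is the partner of compound 1: the change is trifluoromethyl in place of bromo on an aromatic carbon, and the place described around it matches word for word. Because the first instance made a 1.6-fold lower number from compound 1 to compound 2 (0.21 log units; within the scatter), the step from compound 3 to compound 4 is expected to be of similar size, namely a 1.6-fold lower number from compound 3 to compound 4 (0.19 log units; within the scatter). With compound 3 as the starting point at 3880 nM, compound 4 is expected to give 2500 nM, in a range from 1000 nM to 6000 nM.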

Compound 4, half-maximal inhibitory concentration: 3140 nM
For compound 4 the middle estimate is 1.3-fold (0.10 log units) below the measured one; measured number inside the range.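

In this assay, putting trifluoromethyl in place of bromo gives a 1.2-fold lower number from compound 3 to compound 4 (0.09 log units; within the scatter), so on this core the change moves the number by no more than repeated measurements of the same compound usually would. Set beside the same change on the core of compound 1, the two steps cannot be told apart: the same change on two cores in this assay, a 1.6-fold lower number (0.21 log units; within the scatter) from compound 1 to compound 2 and a 1.2-fold lower number (0.09 log units; within the scatter) from compound 3 to compound 4, 1.3-fold (0.12 log units) apart, within the scatter of two such steps This shows that the swap behaves alike on these two cores, in that neither step stands out from the scatter, but it does not show that the swap has any real effect on either core, and two pairs of compounds are too few to make a rule for the whole series.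

The compounds shown leave open what a group other than bromo or trifluoromethyl, such as an amine or a carboxylic acid, would do at this same place, on the aromatic carbon meta to the hydroxy group and para to the large group. They also leave open whether the agreement would hold on a third core, or for a change that gives a step large enough to stand clear of the scatter.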